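Adding a hept-1-yn-1-yl chain to compound 2

A few compounds are considered here, and "the series" means these few. Any claim that something is new, unique, unknown or untested is made for them only; others in the source may bear on it.

Of the compounds shown here, two have been measured in a functional assay on HEL cells (Homo sapiens); on this read-out higher numbers stand for lower toxicity in this test and lower numbers for higher toxicity in this test. Among them, compound 1 `CCCCCCCCc1cc2cn(COCCO)c(O)nc-2n1` gives a true number, 65000 nM.

Compound 2 `O=c1nc2occc2cn1COCCO` gives only a limit of the assay, > 200000 nM, so its exact position on the scale is not known.

Compound 3 `CCCCCC#Cc1cc2cn(COCCO)c(=O)nc2o1` is compound 2 with one change. Hept-1-yn-1-yl takes the place of hydrogen on an aromatic carbon of a five-membered aromatic ring with 1 oxygen, part of a fused or bridged system of two rings, next to the ring oxygen (hept-1-yn-1-yl in place of hydrogen on an aromatic carbon).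

Within the data shown here, no measured pair of compounds shows the size of such a change, so any forecast here is uncertain. In this assay, a moderate step towards lower numbers, meaning higher toxicity in this test, is expected. Among the measured compounds shown here, this expectation leans on compound 1 at 65000 nM, the one compound here that bears a long chain and also has a number. The expected change is an at least 2.5-fold lower number from compound 2 to compound 3 (0.39 log units; beyond the scatter). Compound 3 is estimated at 80000 nM, with an expected range of 25000 nM to 200000 nM.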

Compound 3, half-maximal cytotoxic concentration: > 50000 nM
Compound 3: a limit, no number; the forecaster's own chance of this, stated with the estimate: 30%; the middle value is on the limit's open side.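

In this assay compound 3 gives only a limit, > 50000 nM. Compound 2 also gives only a limit, > 200000 nM. Among these compounds, these two limits leave no step from compound 2 to compound 3 that can be read. From the compounds shown here alone, whether hept-1-yn-1-yl in place of hydrogen changes the half-maximal cytotoxic concentration at all, and in which direction, stays open.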